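Longer Unsaturated Ester on the Shared Core

The source may report more compounds than this note shows. Statements on the series, on what has been measured and on what is new or still open speak of the compounds shown alone.

Measured so far:
compound 1 `CCCCCCCC(=O)O[C@H]1[C@H](O)[C@H](n2ccc(N)nc2=O)O[C@@H]1CO`: 0.1 ug/mL
compound 2 `C=CCCCCCCCCC(=O)O[C@H]1[C@H](O)[C@H](n2ccc(N)nc2=O)O[C@@H]1CO`: 0.05 ug/mL

Both compounds were tested in a functional assay on HeLa cells (Homo sapiens) for cytotoxicity, read by cell counting, with a stated time of 48 h; on this read-out higher numbers stand for an effect only at larger amounts of compound and lower numbers for an effect already at smaller amounts. Compound 1 gives 0.1 ug/mL, the higher of the two numbers; the nearest is compound 2, reached by a 2.0-fold lower number from compound 1 to compound 2 (0.30 log units; within the scatter), which stays within the scatter.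

Compound 3 `CCCCCCC/C=C\C(=O)O[C@H]1[C@H](O)[C@H](n2ccc(N)nc2=O)O[C@@H]1CO` differs from compound 1 at the ester: a group of 9 heavy atoms (9 carbon; no ring) in place of a group of 7 heavy atoms (7 carbon; no ring), on a carbonyl carbon. Within the data shown here, the one measured step that bears on this is the extension of the same chain by an allyl in place of hydrogen on a saturated chain carbon, seven bonds along the chain from a carbonyl carbon, giving a 2.0-fold lower number from compound 1 to compound 2 (0.30 log units; within the scatter). That step did not leave the scatter, so lengthening the chain by a few carbons, even with a double bond, is not expected to move the number far. The expected step is a 1.4-fold lower number from compound 1 to compound 3 (0.15 log units; within the scatter), leaning slightly toward lower numbers. Compound 3 is therefore estimated at 0.07 ug/mL, with a range from 0.02 ug/mL to 0.25 ug/mL.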

Compound 3, concentration for half-maximal effect: 0.06 ug/mL
The estimate for compound 3 lay 1.2-fold (0.07 log units) above the measured number; low and high end bracket the measured number.
By their numbers in this assay, from the lowest: compounds 2, 3 and 1 (each within the scatter of the next).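

In this assay the exchange of heptyl for a group of 9 heavy atoms with 1 double bond, on a carbonyl carbon, gives a 1.7-fold lower number from compound 1 to compound 3 (0.22 log units; within the scatter) and so stays close to the parent. Taken with a 2.0-fold lower number from compound 1 to compound 2 (0.30 log units; within the scatter) on the same ester chain, this shows that a second longer unsaturated chain, built differently from that of compound 2, also keeps the number within the scatter of compound 1. Nothing measured here accounts for this result.

The compounds shown leave open how a saturated chain of the same length would compare, so the double bond cannot be told apart from the added length. They also leave open whether a much longer chain, or an amine or a carboxylic acid at the chain end, would move the number beyond the scatter.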